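Removing the Methoxy from the Cinnamoyl Ring of a Chalcone

The compounds below may be only part of what the source reports. "The series", "measured", "known", "first", "only" and "open" are said of these compounds alone.

Compound 1 `COc1cccc(/C=C/C(=O)c2c(OC)cc(OC)cc2OC)c1` was tested in a functional assay on Caco-2 cells (Homo sapiens), read by fluorescence and BrdU incorporation, with a stated time of 48 h, tested at 10 uM (on this read-out lower numbers stand for a stronger effect and higher numbers for a weaker effect at the one concentration tested), where compound 1 gives 31%. Compound 2 `COc1cccc(/C=C/C(=O)c2c(O)cc(OC)cc2OC)c1` differs from it only by hydrogen in place of methyl on an oxygen on an aromatic ring, and in this assay compound 2 gives 31%. Among the compounds with values here, the one step measured so far, no change at the digits printed from compound 1 to compound 2 (within the scatter), thus shows no movement beyond the scatter, and compound 1 stands level with compound 2 at the digits printed.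

Compound 3 `COc1cc(OC)c(C(=O)/C=C/c2ccccc2)c(OC)c1` has not yet been measured. It differs from compound 1 by hydrogen in place of methoxy on an aromatic carbon; seen one bond further out, a 3-methoxyphenyl becomes a phenyl. Within the data shown here, no measured step touches this ring, so the step from compound 1 to compound 2, which concerns an oxygen on the other ring, bears on it only as a sign that a single small change left this assay unmoved.

On that basis compound 3 is expected to give 35%, with a range from 15% to 60%, and the step of a number 4 percentage points higher from compound 1 to compound 3 (within the scatter) is estimated to lie within the scatter.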

Compound 3, a percentage reported as activity, at one concentration (the size of the read-out at that concentration, not a potency): 38%
Compound 3: the middle estimate sits 3 percentage points below what was measured; low and high end bracket the measured number.
By their numbers in this assay, from the lowest: compounds 1, 2 and 3 (each within the scatter of the next).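

In this assay the change from 3-methoxyphenyl to phenyl gives a number 7 percentage points higher from compound 1 to compound 3 (within the scatter), so this position, meta to a large group, now has a measured step of its own, and the methoxy there can give way to hydrogen without the read-out leaving the scatter. Together with the earlier step on an oxygen of the other ring, this means that single small changes on both rings of the core of compound 1 have now left the read-out within the scatter, although only at the one concentration tested, which gives no potency. No measurement available here speaks to why the read-out stays put at this position.

What remains open is whether a group of a different kind on this aromatic carbon, such as an amine or a carboxylic acid, would move the read-out beyond the scatter, since hydrogen and methoxy are the only two occupants shown. Also open, going by these compounds, is whether a longer chain on that oxygen in place of methoxy would do so, and whether the two single changes combined in one compound would stay within the scatter.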